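This account rests on a few compounds, and the source may have more. Where it says the series, first, only, none or still open, it means among the compounds named here.

Measured so far:

Compound 1, `CC(C)(C)C1=NN(c2cccc(Cl)c2)C(c2ccc(O)cc2)C1`, gives 43.5% in an assay on isolated protein for inhibition of protein kinase C iota type (Homo sapiens), tested at 20 uM; on this read-out lower numbers stand for less inhibition and higher numbers for more inhibition at the one concentration tested (going by the name of the read-out).
Compound 2, `CC(C)(C)C1=NN(c2ccc(F)c(Cl)c2)C(c2ccc(O)cc2)C1`, gives 31.6% in this assay.
Compound 3, `Oc1ccc(C2CC(c3ccccc3O)=NN2c2cccc(Cl)c2)cc1F`, gives 25.2% in this assay.

Compound 2 differs from compound 1 by fluoro in place of hydrogen on an aromatic carbon, and this change gave a number 11.9 percentage points lower from compound 1 to compound 2 (beyond the scatter). Compound 3 is built on a different core from compound 1, a difference that is not broken down here; compound 1 gives the higher number of the two, while compound 3 and compound 2 lie within the usual scatter of each other.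

Compound 4, `Oc1ccccc1C1=NN(c2cccc(Cl)c2)C(c2cc(F)c(O)c(F)c2)C1`, has not yet been measured. It differs from compound 3 by fluoro in place of hydrogen on an aromatic carbon. Going by the values given here, this is the same kind of change as the one from compound 1 to compound 2, but not the same: in compound 2 the new fluoro sits ortho to a chloro group and para to a large group, whereas in compound 4 it sits ortho to a hydroxy group, meta to a fluoro group and meta to a large group. Among the compounds with values here, only one such step has been seen, so the expectation is tentative. Within the data shown here, the expected step is a number 8.2 percentage points lower from compound 3 to compound 4 (within the scatter), estimated because the one earlier change of this kind gave a number 11.9 percentage points lower from compound 1 to compound 2 (beyond the scatter). Compound 4 is therefore expected to give 17%, between 5% and 30%.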

Compound 4, a percentage reported as inhibition, at one concentration (the size of the read-out at that concentration, not a potency): 45.2%
Compound 4: the middle estimate sits 28.2 percentage points below what was measured; the whole stated range lies below it.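

In this assay, turning 3-fluoro-4-hydroxyphenyl into 3,5-difluoro-4-hydroxyphenyl gave a number 20 percentage points higher from compound 3 to compound 4 (beyond the scatter). This shows that, in this series, swapping a hydrogen on an aromatic carbon for fluoro does not bring a fixed gain or loss from one core to another, since even the direction of the step changed: the same change on two cores in this assay, a number 11.9 percentage points lower (beyond the scatter) from compound 1 to compound 2 and a number 20 percentage points higher (beyond the scatter) from compound 3 to compound 4, 31.9 percentage points apart, beyond the scatter of two such steps. It does not show what sets the two steps apart, as they differ both in the core and in where the new fluoro sits, and two steps are too few to give a rule.

Still open, going by these compounds, is how the 3,5-difluoro-4-hydroxyphenyl group behaves on the core of compound 1, a comparison that would help separate the effect of the core from that of the fluoro's place. Also open, on these data alone, is whether a larger or different group at the same ring position, such as a methoxy group, an amine or a carboxylic acid, would move the read-out in the same direction as fluoro.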